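This account rests on a few compounds, and the source may have more. Where it says the series, first, only, none or still open, it means among the compounds named here.

Of the compounds shown here, three sharing a core have been tested in an ADME assay on Vero cells (Chlorocebus sabaeus) for cytotoxicity, read by MTT assay, with a stated time of 72 h; a higher number here means a weaker inhibitor, a lower number a stronger inhibitor. Compound 1 `CCN(CC)C(=O)C1CCCN(c2nc3c(cc2[N+](=O)[O-])c(=O)c(C(=O)O)cn3C2CC2)C1` gives > 136000 nM, which is a limit of the assay and not a number. Compound 2 `CC(C)(C)NC(=O)C1c2ccccc2CCN1c1nc2c(cc1[N+](=O)[O-])c(=O)c(C(=O)O)cn2C1CC1` gives 124000 nM, and compound 3 `CN1CCN(c2nc3c(cc2[N+](=O)[O-])c(=O)c(C(=O)O)cn3-c2ccc(F)cc2)CC1c1ccccc1` gives 124000 nM, so these two stand level with each other. Both are large numbers, and on this scale a large number means weak inhibition.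

Compound 4 `CC(C)(C)NC(=O)C1c2ccccc2CCN1c1nc2c(cc1[N+](=O)[O-])c(=O)c(C(=O)O)cn2C(C)(C)C` differs from compound 2 in a single place, with tert-butyl in place of cyclopropyl on an aromatic nitrogen. Among the compounds with values here, no measured pair shows this swap, so its effect cannot be read directly from the data. Within the data shown here, the only guide is compound 2 itself, at 124000 nM. The estimated 1.1-fold lower number from compound 2 to compound 4 (0.05 log units; within the scatter) in this assay is therefore expected to stay within the scatter, with no clear direction. Compound 4 is estimated at 110000 nM, with an expected range from 55000 nM to 135000 nM.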

Compound 4, half-maximal inhibitory concentration: 120000 nM
Compound 4: middle estimate off by 1.1-fold (0.04 log units), on the low side; the range from low to high includes it.
By their numbers in this assay, from the lowest: compounds 4, 2 and 3 (each within the scatter of the next). At a limit, above all of these: compound 1.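

Within the data shown here, the step from cyclopropyl to tert-butyl on the aromatic nitrogen gives the first direct reading of a change at this position in this assay: a 1.0-fold lower number from compound 2 to compound 4 (0.01 log units; within the scatter). A three-membered ring of carbon gives way to a group with no ring and one more heavy atom, yet the two compounds stand level, so this position tolerates that particular swap in this cell test. Compound 1 gives a limit and not a number, so this assay has a ceiling and any further weakening would have little room to show: the limit of > 136000 nM in this assay, at which 1 of the 4 values shown sits.

From the compounds shown here alone, whether a chain carrying an amine or a carboxylic acid on this aromatic nitrogen would move the number remains open. Also open, going by these compounds, is whether the same swap would read the same way with a different group, such as a simple piperazine, on the other side of the shared core.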